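Extending an Ethoxy Chain by One Carbon

A few compounds are considered here, and "the series" means these few. Any claim that something is new, unique, unknown or untested is made for them only; others in the source may bear on it.

Compound 1 `CCOc1cc(C)c(-c2cccc(COc3ccc(OCC(=O)O)c(F)c3)c2)c(C)c1` carries an ethoxy group on its core. Going by the values given here, in a physicochemical assay for lipophilicity, using the shake flask method, in phosphate buffer, measured as octanol-water partition, with a stated time of 24 h, at pH 7.4, tested at 100 uM (a higher number here means a more lipophilic compound, a lower number a more polar compound), compound 1 gives 3.48, the only number available for this set. For compound 2 `Cc1cc(OCCCS(C)(=O)=O)cc(C)c1-c1cccc(COc2ccc(N(CC(=O)O)C(=O)c3ccccc3)cc2)c1` the outcome in this assay is "not determined" (no result reported), so no second number exists. Compound 3 `CCCOc1cc(C)c(-c2cccc(COc3ccc(OCC(=O)O)c(F)c3)c2)c(C)c1` differs from compound 1 by a single change: methyl in place of hydrogen on a saturated chain carbon, two bonds along the chain from an oxygen on an aromatic ring. Among the compounds with values here, no measured pair shows what this change does, so the expectation rests on the change itself. A modest rise, somewhat beyond the usual scatter, is expected, with the step estimated at a number 0.42 log units higher from compound 1 to compound 3 (beyond the scatter) in this assay. Compound 3 is therefore expected to give 3.9, within 3.5 to 4.3.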

Compound 3, distribution coefficient: 3.64
Estimate against measurement, compound 3: 0.26 log units above; measured number inside the range.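

In this assay the change from ethoxy to propoxy gives a number 0.16 log units higher from compound 1 to compound 3 (within the scatter) so this first measured pair shows that adding one methyl at this position leaves a difference too small to separate from repeat measurements. This holds only for this single pair on the shared core. Nothing shown here explains the size of the step. Still open, going by these compounds, is whether a longer chain such as butoxy would move the value beyond the scatter. Also open, on these data alone, is what an amine or a hydroxyl group at the end of the chain would do.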